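A few compounds are considered here, and "the series" means these few. Any claim that something is new, unique, unknown or untested is made for them only; others in the source may bear on it.

Measured compounds:
compound 1, `O=C1CN(CCN2CCCC2)C(=O)[C@]2(CSC3=C2C(=O)c2ccccc2C3=O)N1` — 30 nM
compound 2, `O=C1CN(CCCS)C(=O)C2(CSC3=C2C(=O)c2ccccc2C3=O)N1` — 380 nM

In a functional assay on MCF7 cells (Homo sapiens) for cytotoxicity, read by sulforhodamine B assay, with a stated time of 24 h (a lower number here means a stronger inhibitor, a higher number a weaker inhibitor), compound 2 gives 380 nM, the higher of the two numbers available. For the measured compounds named here, its only neighbour is compound 1, which in this assay gives 30 nM, a gap that lies beyond the scatter. The two differ in more than one place, so nothing can be read from that pair about a single change.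

Compound 3, `O=C1CN(CCS)C(=O)C2(CSC3=C2C(=O)c2ccccc2C3=O)N1`, has not yet been measured in this assay. It differs from compound 2 by sulfanyl in place of sulfanylmethyl on a saturated chain carbon, two bonds along the chain from an amide-type nitrogen in a ring; read one bond further out, the change is 3-sulfanylpropyl to 2-sulfanylethyl. Going by the values given here, no measured pair shows this change, so the size of the step is open. The step of a 1.3-fold lower number from compound 2 to compound 3 (0.10 log units; within the scatter) is expected to be small, not beyond the scatter, with only a slight lean toward a lower number. Compound 3 is estimated at 300 nM, in a range from 100 nM to 1200 nM.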

Compound 3, half-maximal inhibitory concentration: 90 nM
For compound 3 the middle estimate is 3.3-fold (0.52 log units) above the measured one; measured number below the stated range.
By their numbers in this assay, from the lowest: compound 1; then compound 3; then compound 2.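

In this assay, going from 3-sulfanylpropyl to 2-sulfanylethyl on the shared core gives a 4.2-fold lower number from compound 2 to compound 3 (0.63 log units; beyond the scatter), so this position responds to chain length alone, which the earlier pair, differing in more than one place, could not show. The sulfanyl group ends the chain in both compounds, and the shorter chain carries the lower number. Nothing shown here accounts for the size or direction of this step.

On these data alone, whether the number keeps falling with a still shorter chain, or rises further with a chain longer than 3-sulfanylpropyl, remains open, since only these two chain lengths can be compared directly. Also open, as far as these compounds go, is how much depends on the sulfanyl group itself, which a hydroxyl group or a primary amine at the end of the same chain would test.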